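Hydroxy on the piperidin-1-yl ring of compound 2

The source may hold more compounds than are shown below. What is called first, only, known or untested is meant among the compounds shown, and "the series" means these compounds.

Within the data shown here, on a functional assay on Huh-5-2 cells (Homo sapiens), read by MTT assay (on this read-out higher numbers stand for lower toxicity in this test and lower numbers for higher toxicity in this test), compound 1 (`CN(C)C(=O)c1ccc(-c2ccc(Cl)cc2)c(COc2ccc(-c3nc4cc(C(=O)O)ccc4n3C3CCCCC3)c(F)c2)c1`) gives 26000 nM and compound 2 (`O=C(O)c1ccc2c(c1)nc(-c1ccc(OCc3cc(C(=O)N4CCCCC4)ccc3-c3ccc(Cl)cc3)cc1F)n2C1CCCCC1`) gives 24000 nM with the two numbers within the scatter of each other, so compound 2 has no separate standing among the two values so far.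

The change to compound 3 (`O=C(O)c1ccc2c(c1)nc(-c1ccc(OCc3cc(C(=O)N4CCC(O)CC4)ccc3-c3ccc(Cl)cc3)cc1F)n2C1CCCCC1`) is hydroxy in place of hydrogen on a saturated ring carbon and reads in words as hydroxy in place of hydrogen on a saturated ring carbon, that is, piperidin-1-yl to 4-hydroxypiperidin-1-yl.

Among the measured compounds shown here, only one measured step bears on this group: a 1.1-fold lower number from compound 1 to compound 2 (0.03 log units; within the scatter) for piperidin-1-yl in place of dimethylamino on a carbonyl carbon. That step stayed within the scatter. For the measured compounds named here, no measured compound carries a hydroxy group, so the series offers no direct measure of this change, and the expectation rests on that single small step.

The expected step is a 1.1-fold higher number from compound 2 to compound 3 (0.05 log units; within the scatter) and none beyond the scatter is expected in either direction. On this assay compound 3 is estimated at 27000 nM within an expected range of 13000 nM to 55000 nM for now.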

Compound 3, half-maximal cytotoxic concentration: 26000 nM
Compound 3: middle estimate off by 1.0-fold (0.02 log units), on the high side, within the range that was stated.
By their numbers in this assay, from the lowest: compounds 2, 1 and 3 (each within the scatter of the next).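

In this assay, hydroxy on the saturated ring carbon, three ring bonds from the ring nitrogen, gives a 1.1-fold higher number from compound 2 to compound 3 (0.03 log units; within the scatter). Among these compounds, this is the first reading at this ring carbon, and a group with a hydrogen-bond donor and a hydrogen-bond acceptor enters there without a step beyond the scatter. The wider replacement on the carbonyl carbon gives no change at the digits printed from compound 1 to compound 3 (within the scatter), so dimethylamino, piperidin-1-yl and 4-hydroxypiperidin-1-yl now form a set of three amide groups with all their pairwise steps within the scatter, and nothing available accounts for this flat reading.

Still open, as far as these compounds go, is whether an amine, a carboxylic acid or a longer chain ending in hydroxy on the same ring carbon would give a step beyond the scatter, or whether this position stays as flat with those groups as it does with hydroxy. Also open is whether hydroxy on a different carbon of the six-membered ring would read the same, since the three compounds shown cover only this one placement.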